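The source may hold more compounds than are shown below. What is called first, only, known or untested is meant among the compounds shown, and "the series" means these compounds.

Measured so far: compound 1 `O=C(O)CSc1nnc(Br)n1Cc1ccc(Br)c2ccccc12`, which gives 94 nM in an assay on HEK293 cells for inhibition of solute carrier family 22 member 12 (Homo sapiens); on this read-out lower numbers stand for stronger inhibition and higher numbers for weaker inhibition; compound 2 `O=C(CSc1nnc(Br)n1Cc1ccc(Br)c2ccccc12)NO`, which gives 640 nM in this assay; and compound 3 `O=S(=O)(CSc1nnc(Br)n1Cc1ccc(Br)c2ccccc12)Nc1cncc(C(F)(F)F)c1`, which gives 6380 nM in this assay.

Compound 3 thus holds the highest number of the three, with both compound 2 and compound 1 giving lower numbers by gaps beyond the scatter. Compound 4 `O=S(=O)(CSc1nnc(Br)n1Cc1ccc(Br)c2ccccc12)Nc1cccnc1Br` differs from compound 3 by 2-bromopyridin-3-yl in place of 5-(trifluoromethyl)pyridin-3-yl on a sulfonamide nitrogen. Within the data shown here, the only measured step, a 6.8-fold higher number from compound 1 to compound 2 (0.83 log units; beyond the scatter), alters the carbonyl end of the shared core and not the ring on the sulfonamide nitrogen, so it offers no direct precedent for this change. Among the measured compounds shown here, with no comparable step available, compound 4 is expected to stay near compound 3, with a 1.1-fold lower number from compound 3 to compound 4 (0.03 log units; within the scatter) not beyond the scatter. Compound 4 is therefore estimated at 6000 nM, in the range 2000 nM to 20000 nM.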

Compound 4, half-maximal inhibitory concentration: 280 nM
Estimate against measurement, compound 4: 21-fold (1.33 log units) above, and the stated range ends above it.
By their numbers in this assay, from the lowest: compound 1; then compound 4; then compound 2; then compound 3.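

The ring on the sulfonamide nitrogen proves a sensitive point in this assay: 2-bromopyridin-3-yl in place of 5-(trifluoromethyl)pyridin-3-yl gives a 23-fold lower number from compound 3 to compound 4 (1.36 log units; beyond the scatter). The earlier compounds shown here had not varied this ring, and this large step comes with no change in the counted hydrogen-bond donors or acceptors. Nothing available accounts for the size of this step.

The swap alters both the substituent and its place on the pyridine, so the two contributions remain unseparated. Going by these compounds, whether an unsubstituted pyridin-3-yl, or chlorine in place of the bromine, would read closer to compound 3 or compound 4 stays open.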